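The compounds below may be only part of what the source reports. "The series", "measured", "known", "first", "only" and "open" are said of these compounds alone.

Four close relatives built on one shared core are compared here. Compound 1 `CCn1c(=O)c2[nH]c(Cc3ccccc3)nc2n(Cc2ccco2)c1=O` carries a benzyl group; in an assay on HEK293 cells for displacement of a labelled ligand from adenosine receptor A2b (Homo sapiens) (on this read-out lower numbers stand for stronger inhibition and higher numbers for weaker inhibition), compound 1 gives 162 nM. Compound 2 `CCn1c(=O)c2[nH]c(Cc3ccco3)nc2n(Cc2ccco2)c1=O` differs from compound 1 by furan-2-yl in place of phenyl on a saturated chain carbon bound to an aromatic carbon; in this assay compound 2 gives 126 nM, and the step is a 1.3-fold lower number from compound 1 to compound 2 (0.11 log units; within the scatter). Compound 3 `CCn1c(=O)c2c(nc(Cc3ccccc3)n2C)n(Cc2ccco2)c1=O` differs from compound 1 by methyl in place of hydrogen on an aromatic nitrogen; in this assay compound 3 gives 12.9 nM, a step of a 13-fold lower number from compound 1 to compound 3 (1.10 log units; beyond the scatter), and compound 3 therefore shows the lowest number of the three measured compounds, beyond the scatter from both compound 1 and compound 2.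

Compound 4 `CCn1c(=O)c2c(nc(Cc3ccco3)n2C)n(Cc2ccco2)c1=O` has not yet been measured in this assay. It differs from compound 3 by furan-2-yl in place of phenyl on a saturated chain carbon bound to an aromatic carbon. This is the same change as the one from compound 1 to compound 2, made at the same place, and it occurs twice among the compounds shown; the two cores on which it is made differ by methyl in place of hydrogen on an aromatic nitrogen. Since the change gave a step of a 1.3-fold lower number from compound 1 to compound 2 (0.11 log units; within the scatter) on the core of compound 1, and nothing here shows that the core of compound 3 would answer it differently, the expected step in this assay is a 1.3-fold lower number from compound 3 to compound 4 (0.11 log units; within the scatter), which would again lie within the scatter like the earlier one. Because compound 3 gives 12.9 nM, compound 4 is estimated at 10 nM, with a likely range from 5 nM to 22 nM.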

Compound 4, inhibition constant: 13.8 nM
Compound 4: middle estimate off by 1.4-fold (0.14 log units), on the low side; the range from low to high includes it.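

On the saturated chain carbon bound to an aromatic carbon, furan-2-yl in place of phenyl gives a 1.1-fold higher number from compound 3 to compound 4 (0.03 log units; within the scatter), so this swap again leaves the number in this assay within the scatter, and the two cores agree: the same change on two cores in this assay, a 1.3-fold lower number (0.11 log units; within the scatter) from compound 1 to compound 2 and a 1.1-fold higher number (0.03 log units; within the scatter) from compound 3 to compound 4, 1.4-fold (0.14 log units) apart, within the scatter of two such steps

The other change, methyl in place of hydrogen on an aromatic nitrogen, gives a 9.1-fold lower number from compound 2 to compound 4 (0.96 log units; beyond the scatter), a step beyond the scatter that appears with furan-2-yl as it did with phenyl: the same change on two cores in this assay, a 13-fold lower number (1.10 log units; beyond the scatter) from compound 1 to compound 3 and a 9.1-fold lower number (0.96 log units; beyond the scatter) from compound 2 to compound 4, 1.4-fold (0.14 log units) apart, within the scatter of two such steps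

Across these four compounds, then, each change gives about the same step whatever stands at the other place, so its effect could be carried from one core to the other; but this rests on a single pair of steps for each change, and it shows neither that the same holds for other groups or cores nor why the methyl brings the number down.

The compounds shown leave open whether a longer chain such as propyl on that aromatic nitrogen would give a step like the methyl's. They also leave open whether a group of another kind on the saturated chain carbon, such as an amine or a carboxylic acid, would stay as independent of the nitrogen substituent as furan-2-yl and phenyl do here.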